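Swapping the Aryl Group on a Triazole Amide

The source may report more compounds than this note shows. Statements on the series, on what has been measured and on what is new or still open speak of the compounds shown alone.

Compound 1 `CC(C)n1ncc2c(C(=O)Nc3ccccc3)cccc21` gives 23700 nM in a functional assay on HepG2 cells (Homo sapiens) for inhibition, read by MTT assay, with a stated time of 72 h; a lower number here means a stronger inhibitor, a higher number a weaker inhibitor.
Compound 2 `CC(C)n1ncc2c(C(=O)NCc3cn(-c4ccc(F)cc4)nn3)cccc21` reaches only the assay limit, > 40000 nM.

The number for compound 2 is therefore a limit, not a measured value (the limit of > 40000 nM in this assay, at which 1 of the 2 values shown sits), and where it truly stands is not known. Compound 3 `Cc1cccc(-n2cc(CNC(=O)c3cccc4c3cnn4C(C)C)nn2)c1` differs from compound 2 by 3-methylphenyl in place of 4-fluorophenyl on an aromatic nitrogen. Among the compounds with values here, no measured pair shows what such a swap does, so no step beyond the usual scatter is expected. Compound 3 is expected at 40000 nM, within 15000 nM to 100000 nM, meaning a number no higher from compound 2 to compound 3 (the limit leaves the size open).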

Compound 3, half-maximal inhibitory concentration: > 40000 nM
Compound 3: only a limit was reported; the forecaster's own chance of this, stated with the estimate: 65%; the middle value lies on the limit itself.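

Compound 3 gives only a limit (> 40000 nM). Within the data shown here, compound 2 also stands at a limit, so no step between compound 2 and compound 3 can be read. From the compounds shown here alone, the true strength of both compounds, and what 3-methylphenyl in place of 4-fluorophenyl does, stays open.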